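A few compounds are considered here, and "the series" means these few. Any claim that something is new, unique, unknown or untested is made for them only; others in the source may bear on it.

Three compounds were measured in a functional assay on MKN-45 cells (Homo sapiens) for inhibition, read by MTT assay, with a stated time of 72 h; on this read-out lower numbers stand for stronger inhibition and higher numbers for weaker inhibition:
compound 1 `COc1cc2c(Oc3ccc(NC(=O)c4nn(-c5ccccc5C(F)(F)F)c(=O)cc4C)cc3F)ccnc2cc1OCCCN1CCCCC1` gives 90 nM;
compound 2 `COc1cc2c(Oc3ccc(NC(=O)c4nn(-c5ccccc5C(F)(F)F)c(=O)cc4C)cc3F)ccnc2cc1OCCCN1CCC(C)CC1` gives 60 nM;
compound 3 `COc1cc2c(Oc3ccc(NC(=O)c4nn(-c5cccc(F)c5)c(=O)cc4C)cc3F)ccnc2cc1OCCCN1CCCCC1` gives 130 nM.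

Compound 2 differs from compound 1 by methyl in place of hydrogen on a saturated ring carbon, a change that produced a 1.5-fold lower number from compound 1 to compound 2 (0.18 log units; within the scatter). Compound 3 has a different core from compound 1, the difference being (3-fluorophenyl in place of 2-(trifluoromethyl)phenyl on an aromatic nitrogen), and this gave a 1.4-fold higher number from compound 1 to compound 3 (0.16 log units; within the scatter). Compound 4 `COc1cc2c(Oc3ccc(NC(=O)c4nn(-c5cccc(F)c5)c(=O)cc4C)cc3F)ccnc2cc1OCCCN1CCC(C)CC1` keeps the core of compound 3 and carries the same change seen between compound 1 and compound 2, namely (methyl in place of hydrogen on a saturated ring carbon), at the same place in the ring in both pairs. Among the measured compounds shown here, the step is expected to be a 1.4-fold lower number from compound 3 to compound 4 (0.16 log units; within the scatter), set beside the earlier one, because a 1.5-fold lower number from compound 1 to compound 2 (0.18 log units; within the scatter) is the only guide available. Compound 4 is therefore estimated to give 90 nM in this assay, with a likely range from 50 nM to 170 nM.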

Compound 4, half-maximal inhibitory concentration: 140 nM
Compound 4: the middle estimate sits 1.6-fold (0.19 log units) below what was measured; low and high end bracket the measured number.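

In this assay, the change from piperidin-1-yl to 4-methylpiperidin-1-yl gave a 1.1-fold higher number from compound 3 to compound 4 (0.03 log units; within the scatter), which agrees with the same change on the other core: the same change on two cores in this assay, a 1.5-fold lower number (0.18 log units; within the scatter) from compound 1 to compound 2 and a 1.1-fold higher number (0.03 log units; within the scatter) from compound 3 to compound 4, 1.6-fold (0.21 log units) apart, within the scatter of two such steps. The change on the aromatic nitrogen, now with 4-methylpiperidin-1-yl in place, gave a 2.3-fold higher number from compound 2 to compound 4 (0.37 log units; beyond the scatter), and this also agrees with its earlier step: the same change on two cores in this assay, a 1.4-fold higher number (0.16 log units; within the scatter) from compound 1 to compound 3 and a 2.3-fold higher number (0.37 log units; beyond the scatter) from compound 2 to compound 4, 1.6-fold (0.21 log units) apart, within the scatter of two such steps. Neither change shows a detectable dependence on the core in these four compounds, but each comparison rests on only two steps, and the methyl steps lie within the scatter, so no effect of the methyl is shown on either core.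

The compounds shown leave open how a morpholine in place of the piperidine would carry between these cores. The same holds for an unsubstituted phenyl on the aromatic nitrogen.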